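The source may hold more compounds than are shown below. What is called first, only, known or untested is meant among the compounds shown, and "the series" means these compounds.

Measured in a functional assay on A549 cells (Homo sapiens) for antiproliferative activity, read by MTT assay, with a stated time of 72 h; a lower number here means a stronger inhibitor, a higher number a weaker inhibitor:

- Compound 1 `O=C(N/N=C/c1ccc(F)cc1)Nc1ccc(Oc2ccnc3[nH]ccc23)cc1`: 1430 nM
- Compound 2 `CCN(CC)CCn1cccc1/C=N/NC(=O)Nc1ccc(Oc2ccnc3[nH]ccc23)cc1`: 3570 nM

Of these two numbers, compound 2 has the higher one at 3570 nM, which makes it the weaker inhibitor of the pair. Its gap to compound 1 at 1430 nM lies beyond the usual scatter of repeated measurements.

The next compound, compound 3 `O=C(N/N=C/c1cccn1CCCN1CCCC1)Nc1ccc(Oc2ccnc3[nH]ccc23)cc1`, has not yet been measured. It differs from compound 2 in one place: (pyrrolidin-1-yl)methyl in place of diethylamino on a saturated chain carbon, two bonds along the chain from an aromatic nitrogen. Put simply, (pyrrolidin-1-yl)methyl stands in place of diethylamino on a saturated chain carbon, two bonds along the chain from an aromatic nitrogen. Cut one bond further out, the same difference reads 2-(diethylamino)ethyl to 3-(pyrrolidin-1-yl)propyl.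

Among the compounds with values here, no measured pair shows what this kind of change does, so the best starting point is compound 2 itself at 3570 nM. In this assay, no change beyond the scatter is expected. The expected size of the move is a 1.2-fold lower number from compound 2 to compound 3 (0.08 log units; within the scatter). For compound 3 the estimated value is 3000 nM, with an expected range from 1100 nM to 8000 nM.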

Compound 3, half-maximal inhibitory concentration: 1300 nM
Compound 3: middle estimate off by 2.3-fold (0.36 log units), on the high side, within the range that was stated.
By their numbers in this assay, from the lowest: compounds 3 and 1 (each within the scatter of the next); then compound 2.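

In this assay the chain on the aromatic nitrogen proves to be a place where the number can move: changing from diethylamino to (pyrrolidin-1-yl)methyl gives a 2.7-fold lower number from compound 2 to compound 3 (0.44 log units; beyond the scatter) and so shifts activity by a modest but real step. This is the first pair shown that differs in only one place, and so the first direct reading of this position. The change does two things at once, since the end of the chain closes into a five-membered non-aromatic ring and the chain also grows, as the change from 2-(diethylamino)ethyl to 3-(pyrrolidin-1-yl)propyl shows, and no separate measurement explains why the number moved.

The compounds shown leave open whether the ring or the extra chain length carries the step, a question that 2-(pyrrolidin-1-yl)ethyl and 3-(diethylamino)propyl chains would help to separate. Also open, on these data alone, is how far the trend extends, for instance to a piperidine or morpholine ring at the end of the chain, or to a longer chain still.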